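The compounds below may be only part of what the source reports. "The series", "measured", "known", "first", "only" and "open" are said of these compounds alone.

Measured so far:
compound 1 `COc1ccc(SCc2ccc(C(=O)Nc3ccccc3N)cc2)cc1` — 70.7%
compound 2 `Nc1ccccc1NC(=O)/C=C/c1ccc(CSc2cccc(F)c2)cc1` — 56.6%
compound 3 `Nc1ccccc1NC(=O)/C=C/c1ccc(CSc2ccc(C(F)(F)F)cn2)cc1` — 56.5%

All three numbers come from a functional assay on A549 cells (Homo sapiens) for inhibition, read by CCK-8 assay, with a stated time of 72 h, tested at 8 uM; on this read-out higher numbers stand for more inhibition of growth at the one concentration tested and lower numbers for less inhibition of growth. Compound 1 stands highest of the three; the gaps down to compound 2 and to compound 3 both lie beyond the scatter. Compounds 2 and 3, built on a different core from compound 1, sit within the scatter of each other: a number 0.1 percentage points lower from compound 2 to compound 3 (within the scatter), so exchanging the ring on the sulfur left the read-out essentially where it was.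

Compound 4 `Nc1ccccc1NC(=O)c1ccc(CSc2ccc(Cl)cc2)cc1` shares the core of compound 1 and differs from it at one place: chloro in place of methoxy on an aromatic carbon. Among the compounds with values here, no measured step changes this group on this core. Within the data shown here, the one step in which the ring on the sulfur is altered, a number 0.1 percentage points lower from compound 2 to compound 3 (within the scatter), stays within the scatter, which is a weak hint that such exchanges on the sulfur-bound ring do little here. In this assay no step beyond the scatter is expected for compound 4: a number 2.7 percentage points lower from compound 1 to compound 4 (within the scatter). The estimate for compound 4 is 68%, in the range 55% to 80%.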

Compound 4, percent growth inhibition at one concentration: 50.4%
The estimate for compound 4 lay 17.6 percentage points above the measured number; the whole stated range lies above it.
By their numbers in this assay, from the lowest: compounds 4, 3 and 2 (each within the scatter of the next); then compound 1.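

In this assay the exchange of methoxy for chloro, on an aromatic carbon para to a large group, gives a number 20.3 percentage points lower from compound 1 to compound 4 (beyond the scatter) on the shared core. This place on the sulfur-bound ring therefore responds to a single group exchange, and the flat step between compound 2 and compound 3, taken on a different core, does not carry over to this core. No available measurement explains the size of this step.

With only methoxy and chloro shown at this place on this core, two compounds define no trend, and how an amine, a carboxylic acid or an ethoxy group would read here remains open. From the compounds shown here alone, it also remains open whether the same exchange on the core of compound 2 would give a step of similar size.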